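A few compounds are considered here, and "the series" means these few. Any claim that something is new, unique, unknown or untested is made for them only; others in the source may bear on it.

Measured compounds:
Compound 1, `COc1ccccc1OCCNc1ccc(=O)n(Cc2ccc(OC)c(OCC3CC3)c2)n1`, in a functional assay on SH-SY5Y cells (Homo sapiens) for antiproliferative activity, read by MTT assay, with a stated time of 48 h (a lower number here means a stronger inhibitor of growth, a higher number a weaker inhibitor of growth), compound 1 gives 10500 nM.
Compound 2, `COc1ccccc1OCCNc1ccc(=O)n(Cc2ccc(OC(F)F)c(OCC3CC3)c2)n1`, in this assay compound 2 gives 6300 nM.
Compound 3, `COc1ccccc1OCCNc1cnn(Cc2ccc(OC(F)F)c(OC3CCCC3)c2)c(=O)c1Cl`, in this assay compound 3 gives only a limit, > 100000 nM.

Compounds 1 and 2 share one core and differ in a single place: methyl in place of difluoromethyl on an oxygen on an aromatic ring. That change made the step of a 1.7-fold higher number from compound 2 to compound 1 (0.22 log units; within the scatter). The difference between the core of compound 2 and the core of compound 3 is not broken down here. Compound 3 sits at the limit of > 100000 nM in this assay, at which 1 of the 3 values shown sits, and is not a number.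

Compound 4, `COc1ccccc1OCCNc1cnn(Cc2ccc(OC)c(OC3CCCC3)c2)c(=O)c1Cl`, has not been measured. It carries the same change on the core of compound 3: methyl in place of difluoromethyl on an oxygen on an aromatic ring. Because a 1.7-fold higher number from compound 2 to compound 1 (0.22 log units; within the scatter) showed hardly any movement, the step that the limit leaves unreadable from compound 3 to compound 4 is expected to be small as well. Compound 4 is therefore expected to stay very weak, near the limit, at an estimated 150000 nM, between 50000 nM and 500000 nM.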

Compound 4, concentration for 50% growth inhibition: 23300 nM
For compound 4 the middle estimate is 6.4-fold (0.81 log units) above the measured one; measured number outside the range, below it.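

On the core of compound 3, putting methyl in place of difluoromethyl gave in this assay an at least 4.2-fold lower number from compound 3 to compound 4 (0.63 log units; beyond the scatter), so the change did not carry over unaltered from the core of compound 2: the same change on two cores in this assay, a 1.7-fold higher number (0.22 log units; within the scatter) from compound 2 to compound 1 and an at least 4.2-fold lower number (0.63 log units; beyond the scatter) from compound 3 to compound 4, at least 7.1-fold (0.85 log units) apart, beyond the scatter of two such steps

The value of compound 3 is a limit and not a number: the limit of > 100000 nM in this assay, at which 1 of the 4 values shown sits.

From the compounds shown here alone, the step on one core was therefore a poor guide to the step on the other here, but the full size of the second step stays unknown, and two cores cannot show which difference between them matters.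

The compounds shown leave open which part of the difference between the two cores goes with the uneven result. They also leave open whether ethyl or trifluoromethyl on that oxygen would behave alike on both cores.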